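The source may report more compounds than this note shows. Statements on the series, on what has been measured and on what is new or still open speak of the compounds shown alone.

Measured compounds, all in an ADME assay on HEK293 cells (Homo sapiens) for inhibition, with a stated time of 72 h; on this read-out higher numbers stand for an effect only at larger amounts of compound and lower numbers for an effect already at smaller amounts:
- compound 1, `C=C(C)C(=O)Nc1cccc(-c2nc3ccccc3s2)c1`, gives only the assay limit > 25000 nM.
- compound 2, `O=C(O)/C=C/C(=O)Nc1cccc(-c2nc3ccccc3s2)c1`, gives only the assay limit > 25000 nM.
- compound 3, `O=C(Nc1cccc(-c2nc3ccccc3s2)c1)c1cnccc1Cl`, likewise gives only the assay limit > 25000 nM.

Compound 3 therefore stands at the same limit as the other two measured members of the series; no number has been obtained for any of them, and none of the three can be ranked against the others. The steps between them, a step that the two limits leave unreadable from compound 1 to compound 2, a step that the two limits leave unreadable from compound 1 to compound 3 and a step that the two limits leave unreadable from compound 2 to compound 3, are all unreadable for this reason, which is summed up by the limit of > 25000 nM in this assay, at which 3 of the 3 values shown sit.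

Compound 4 is `O=C(Nc1cccc(-c2nc3ccccc3s2)c1)c1cnc(Cl)s1`. It differs from compound 3 by 2-chloro-1,3-thiazol-5-yl in place of 4-chloropyridin-3-yl on a carbonyl carbon. Within the data shown here, none of the measured steps gives a readable size, so the only guide is that every change on the carbonyl carbon so far, from a methylethenyl through a carboxyethenyl to a chloropyridinyl, has left the read-out at the limit. A further aromatic ring at this position is expected to stay there too, and the step that the limit leaves unreadable from compound 3 to compound 4 is expected to be no more than scatter. For compound 4 the estimate in this assay is 35000 nM, with a range from 12000 nM to 100000 nM, most probably reported again as a limit only.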

Compound 4, half-maximal effective concentration: > 25000 nM
Compound 4: no number, only a limit (the forecaster's own chance of this, stated with the estimate: 80%); the middle value is on the limit's open side.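

In this assay compound 4 gives > 25000 nM as a limit and not a number. Among these compounds, no step from compound 1, compound 2 or compound 3 to compound 4 can be read, and the series stays where it was: the limit of > 25000 nM in this assay, at which 4 of the 4 values shown sit.

The compounds shown leave open whether any group on the carbonyl carbon gives a measurable value in this read-out.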